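Amino for fluoro on the pendant phenyl of compound 1

The source may hold more compounds than are shown below. What is called first, only, known or untested is meant among the compounds shown, and "the series" means these compounds.

Compound 1 `CCCS(=O)(=O)Nc1ccc(F)c(C(=O)c2n[nH]c3ncc(-c4ccccc4F)cc23)c1F` gives 2% in an assay for binding affinity to dual specificity mitogen-activated protein kinase kinase 4 (Homo sapiens), read by KINOMEscan, tested at 100 nM (a higher number here means a weaker effect of the compound at the concentration tested, a lower number a stronger effect), the lowest number of the three measured, with compound 3 `CCCS(=O)(=O)Nc1ccc(F)c(C(=O)c2n[nH]c3ncc(-c4cccc(O)c4)cc23)c1F` at 2.2% within the scatter of it and compound 2 `CCCS(=O)(=O)Nc1ccc(F)c(C(=O)c2n[nH]c3ncc(-c4cccc(C)c4)cc23)c1F` at 15% the furthest. The change to compound 4 `CCCS(=O)(=O)Nc1ccc(F)c(C(=O)c2n[nH]c3ncc(-c4ccccc4N)cc23)c1F` is amino in place of fluoro on an aromatic carbon. Among the compounds with values here, no measured step swaps a single substituent at that place; the nearest guides are a number 13 percentage points higher from compound 1 to compound 2 (beyond the scatter), a modest rise, and a number 0.2 percentage points higher from compound 1 to compound 3 (within the scatter), within the scatter, where a hydrogen-bond donor and acceptor on the same phenyl left the number unchanged. On that basis a step of a number 2 percentage points higher from compound 1 to compound 4 (within the scatter) is expected, at most slightly higher. Compound 4 is therefore estimated at 4%, between 1% and 15%.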

Compound 4, a percentage reported as activity, at one concentration (the size of the read-out at that concentration, not a potency): 23%
Compound 4: middle estimate off by 19 percentage points, on the low side; measured number above the stated range.
By their numbers in this assay, from the lowest: compounds 1 and 3 (each within the scatter of the next); then compounds 2 and 4 (each within the scatter of the next).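

In this assay this position proves less forgiving than compound 3 suggested: the amino-for-fluoro swap gives a number 21 percentage points higher from compound 1 to compound 4 (beyond the scatter) and the change from 3-hydroxyphenyl to 2-aminophenyl gives a number 20.8 percentage points higher from compound 3 to compound 4 (beyond the scatter). A hydrogen-bond donor on the pendant phenyl therefore does not by itself keep the number low. Compound 4 also shows no separation from the methyl-bearing compound, with a number 8 percentage points higher from compound 2 to compound 4 (within the scatter).

Going by these compounds, whether the rise follows the amino group or its place on the ring stays open, and 3-aminophenyl or 2-hydroxyphenyl would separate the two. No evidence at hand bears on this result.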